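From Methoxyphenyl to Fluorobenzyl: Microsomal Stability Expected

The source may report more compounds than this note shows. Statements on the series, on what has been measured and on what is new or still open speak of the compounds shown alone.

Compound 1, `COc1cccc(CCOc2ccc(-c3c(C)nc(C)c([C@H](OC(C)(C)C)C(=O)O)c3N3CCC(C)(C)CC3)cc2)c1`, in an ADME assay on microsomes from liver (Rattus norvegicus) for metabolic stability, read by LC-MS, tested at 0.5 uM (a lower number here means that the compound disappears faster, a higher number that the compound lasts longer), gives > 2 h, which is a limit of the assay.
Compound 2, `Cc1nc(C)c([C@H](OC(C)(C)C)C(=O)O)c(N2CCC(C)(C)CC2)c1-c1ccc(OCCc2ccc(F)cc2F)cc1`, in this assay gives > 2 h, also a limit of the assay.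

Compound 1 therefore stands at the limit of > 2 h in this assay, at which 2 of the 2 values shown sit. The step that the two limits leave unreadable from compound 1 to compound 2 gives no readable size. Compound 3, `Cc1nc(C)c([C@H](OC(C)(C)C)C(=O)O)c(N2CCC(C)(C)CC2)c1-c1ccc(OCCCc2ccc(F)cc2)cc1`, differs from compound 1 by 4-fluorobenzyl in place of 3-methoxyphenyl on a saturated chain carbon, two bonds along the chain from an oxygen on an aromatic ring. With only a limit to lean on, no step beyond the scatter can be read from it. Compound 3 is expected to give 2.5 h, between 1.2 h and 5 h. This estimate means an expected step that the limit leaves unreadable from compound 1 to compound 3.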

Compound 3, half-life: > 2 h
Compound 3: no number, only a limit; the forecaster's own chance of this, stated with the estimate: 70%; the middle value does not contradict the limit.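

Compound 3 sits at a limit of this assay, as do compound 1 and compound 2, so no step among them can be read: the limit of > 2 h in this assay, at which 3 of the 3 values shown sit.

On these data alone, how long each of the three actually lasts, and whether they differ at all, stays open.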